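The source may report more compounds than this note shows. Statements on the series, on what has been measured and on what is new or still open speak of the compounds shown alone.

Compound 1 `COc1ccc(N)c(C2=NN(C(=O)C3CCCC3)C(C)(C)S2)c1`: 65%
Compound 2 `CCCCC(=O)N1N=C(c2ccccc2N)SC1(C)C`: 39.1%

Of the compounds shown here, two share a core here and have been measured in an assay on isolated protein for inhibition of Nitric oxide synthase, inducible (Homo sapiens), read by scintillation counting, with a stated time of 30 min, tested at 50 uM; on this read-out lower numbers stand for less inhibition and higher numbers for more inhibition at the one concentration tested (going by the name of the read-out). In this assay compound 1 gives 65%. Compound 2 gives 39.1%, the lowest of the two numbers; its nearest neighbour is compound 1, whose value is higher by a margin that lies beyond the usual scatter. Among the measured compounds shown here, no single-point step between these two measured compounds is available, since compound 1 and compound 2 differ in more than one place, so only their two values speak.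

Compound 3 `CC1(C)SC(c2ccccc2N)=NN1C(=O)C1CCCC1` has not yet been measured. It differs from compound 2 in one place: cyclopentyl in place of butyl on a carbonyl carbon. The same cyclopentyl group on the carbonyl is present in compound 1, which is the higher of the two measured values, but compound 1 also carries a further group that compound 3 lacks, so that comparison is only suggestive. In this assay a modest upward step is expected, a number 10.9 percentage points higher from compound 2 to compound 3 (beyond the scatter). Compound 3 is therefore estimated at 50%, with a range from 30% to 70%.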

Compound 3, a percentage reported as inhibition, at one concentration (the size of the read-out at that concentration, not a potency): 42.2%
Compound 3: the middle estimate sits 7.8 percentage points above what was measured; measured number inside the range.
By their numbers in this assay, from the lowest: compounds 2 and 3 (each within the scatter of the next); then compound 1.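

In this assay cyclopentyl in place of butyl on a carbonyl carbon gives a number 3.1 percentage points higher from compound 2 to compound 3 (within the scatter) and so this read-out does not separate the two groups at this place, a point the earlier pair could not settle because compound 1 and compound 2 differ in more than one place. The gap between those two now has a single-place counterpart, since hydrogen in place of methoxy on an aromatic carbon, with the cyclopentylcarbonyl group the same on both sides, gives a number 22.8 percentage points lower from compound 1 to compound 3 (beyond the scatter) and the larger difference in this set therefore goes with the methoxy group and not with the group on the carbonyl. No measurement at hand speaks to why either step has the size it has.

From the compounds shown here alone, whether methoxy carries the same weight with butyl on the carbonyl stays open, as does how a phenyl ring or a longer chain on the carbonyl carbon, or a chlorine or a hydroxyl on the aromatic carbon in place of methoxy, would read. Each number is a reading at one concentration, so none of the three compounds has a potency here.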